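A few compounds are considered here, and "the series" means these few. Any claim that something is new, unique, unknown or untested is made for them only; others in the source may bear on it.

Of the compounds shown here, three sharing one core have been measured in a functional assay on BT-20 cells (Homo sapiens) for cytotoxicity, read by MTT assay, with a stated time of 68 h; a lower number here means a stronger inhibitor, a higher number a weaker inhibitor. Compound 1 `COc1ccc(C(=O)/C=C/c2cccc(OCc3ccccc3)c2)cc1` gives 38300 nM. Compound 2 `O=C(/C=C/c1cccc(OCc2ccccc2)c1)c1ccc([N+](=O)[O-])cc1` gives 80900 nM. Compound 3 `O=C(/C=C/c1cccc(OCc2ccccc2)c1)c1ccccc1` gives 25500 nM. Compound 3 has the lowest number of the three: the step of a 3.2-fold lower number from compound 2 to compound 3 (0.50 log units; beyond the scatter) lies beyond the scatter, while the step of a 1.5-fold lower number from compound 1 to compound 3 (0.18 log units; within the scatter) lies within it, so compound 3 and compound 1 cannot be told apart on these numbers. Within the data shown here, the step of a 2.1-fold higher number from compound 1 to compound 2 (0.32 log units; beyond the scatter) is the only other exchange on that aromatic carbon. Compound 4 `Cc1ccc(C(=O)/C=C/c2cccc(OCc3ccccc3)c2)cc1` follows from compound 3 by methyl in place of hydrogen on an aromatic carbon. Among the measured compounds shown here, no measured step puts a methyl there; the nearest comparisons are the methoxy-to-hydrogen and nitro-to-hydrogen exchanges, one within the scatter and the other modest. A methyl on this aromatic carbon is therefore expected to move the number little, and compound 4 is estimated to show a 1.0-fold higher number from compound 3 to compound 4 (0.01 log units; within the scatter). Compound 4 is expected to give 26000 nM, in a range from 10000 nM to 65000 nM.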

Compound 4, half-maximal inhibitory concentration: 61000 nM
Estimate against measurement, compound 4: 2.3-fold (0.37 log units) below; the range from low to high includes it.
By their numbers in this assay, from the lowest: compounds 3, 1, 4 and 2 (each within the scatter of the next, the first and the last beyond it).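

In this assay, methyl in place of hydrogen on this aromatic carbon, para to a large group, gives a modest step beyond the scatter (a 2.4-fold higher number from compound 3 to compound 4 (0.38 log units; beyond the scatter)), so adding a single carbon here is enough to change the number. Compound 4 cannot be told apart from the nitro or methoxy compounds (a 1.3-fold lower number from compound 2 to compound 4 (0.12 log units; within the scatter); a 1.6-fold higher number from compound 1 to compound 4 (0.20 log units; within the scatter)), and compound 1 goes against any rule that a group on this carbon raises the number, since its step to compound 3 lies within the scatter. No evidence at hand accounts for this step.

The compounds shown leave open whether an amine, a carboxylic acid or a longer chain on this carbon would give a number closer to that of compound 3 or compound 4. They also leave open whether a methyl elsewhere on this ring would produce a similar step.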